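Swapping a Methylpyridine for a Methoxyphenyl: Expected Lipophilicity

A few compounds are considered here, and "the series" means these few. Any claim that something is new, unique, unknown or untested is made for them only; others in the source may bear on it.

Compound 1 `CC[C@@H](Nc1c(C#N)c(-c2ccc(-c3cccnc3C)cc2)nc2cnccc12)C(N)=O` was measured in a physicochemical assay for lipophilicity, read by HPLC, at pH 7.5 (on this read-out lower numbers stand for lower lipophilicity and higher numbers for higher lipophilicity), where compound 1 gives 1.9. Compound 3 `N#Cc1c(-c2ccc(Br)cc2)nc2cnccc2c1NCC(N)=O` gives 1.9 in this assay, so compound 1 and compound 3 stand level at the digits shown, within the usual scatter, and together they are the lowest of the three numbers. Compound 2 `CCOc1ccccc1-c1ccc(-c2nc3cnccc3c(NC(COC)C(N)=O)c2C#N)cc1` gives 2.8 in this assay, a number that lies above compound 1 by more than the scatter, and compound 2 is the furthest from compound 1.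

Compound 4 `CC[C@@H](Nc1c(C#N)c(-c2ccc(-c3cccc(OC)c3)cc2)nc2cnccc12)C(N)=O` has not been measured. It differs from compound 1 in one place: 3-methoxyphenyl in place of 2-methylpyridin-3-yl on an aromatic carbon. The ring that leaves holds a nitrogen as one of its six members; the ring that enters is built of carbon only and carries its single acceptor, an oxygen, outside the ring. Within the data shown here, no measured pair in this set makes this same exchange, so nothing here fixes the size of the step directly. The numbers for compound 1 and compound 2 show that within this series a shift of the size seen between them is possible.

For compound 4 the step from compound 1 is expected to be a rise beyond the scatter, a number 0.80 log units higher from compound 1 to compound 4 (beyond the scatter). Compound 4 is therefore estimated at 2.7, with a range from 2.2 to 3.2.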

Compound 4, distribution coefficient: 2.7
Compound 4: the middle estimate sits on the measured number at the digits printed; the range from low to high includes it.
By their numbers in this assay, from the lowest: compounds 1 and 3 (each within the scatter of the next); then compounds 4 and 2 (each within the scatter of the next).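

In this assay, among these compounds, the exchange of 2-methylpyridin-3-yl for 3-methoxyphenyl on an aromatic carbon, with the rest of compound 1 kept unchanged, gives the first direct reading for this position: a number 0.80 log units higher from compound 1 to compound 4 (beyond the scatter). The earlier compounds shown here could not show this, since none of them formed a pair differing in one place, so the gaps among their numbers could not be tied to any single part of the structure. The new pair shows that the read-out responds to this one exchange even though the two groups match in their counts of hydrogen-bond donors and acceptors, but nothing available explains which feature of the exchange accounts for the step.

Among the compounds shown here, with only one exchange at this position, the ring nitrogen, the methyl and the methoxy cannot be told apart, so a plain phenyl ring or a methoxypyridine ring in the same place would be needed to separate them. As far as these compounds go, how an amine or a carboxylic acid on that ring would read, and whether the same exchange gives a similar step with a different side chain on the shared core, also stay open.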